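The source may report more compounds than this note shows. Statements on the series, on what has been measured and on what is new or still open speak of the compounds shown alone.

Working notes on a series built on one shared core. Compound 1 `C[C@H](NC(=O)C(=O)Nc1ccccn1)C(=O)N[C@@H](CC(=O)O)C(=O)COc1c(F)c(F)cc(F)c1F` carries a pyridin-2-yl group on the amide-type nitrogen; in a functional assay on Jurkat cells (Homo sapiens) for inhibition (on this read-out lower numbers stand for stronger inhibition and higher numbers for weaker inhibition), compound 1 gives 1040 nM. Compound 2 `C[C@H](NC(=O)C(=O)Nc1ccccc1Cl)C(=O)N[C@@H](CC(=O)O)C(=O)COc1c(F)c(F)cc(F)c1F` gives 64 nM in this assay, and compound 3 `C[C@H](NC(=O)C(=O)Nc1cc(C(C)(C)C)ccc1C(C)(C)C)C(=O)N[C@@H](CC(=O)O)C(=O)COc1c(F)c(F)cc(F)c1F` gives 62 nM. Going by the values given here, the one single-point step recorded is a 16-fold lower number from compound 1 to compound 2 (1.21 log units; beyond the scatter). On the numbers shown, compound 2 stands second highest of the three: its nearest neighbour is compound 3, within the scatter of it, while compound 1 sits beyond the scatter above it.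

Compound 4 `C[C@H](NC(=O)C(=O)Nc1ccccc1Oc1ccccc1)C(=O)N[C@@H](CC(=O)O)C(=O)COc1c(F)c(F)cc(F)c1F` has not yet been measured in this assay. Relative to compound 2 the change is phenoxy in place of chloro on an aromatic carbon, the phenoxy entering on an aromatic carbon of a six-membered aromatic ring of carbon only, ortho to a large group. Among the compounds with values here, no recorded step swaps one substituent for another on that ring, so the measured steps bear only indirectly. The step of a 16-fold lower number from compound 1 to compound 2 (1.21 log units; beyond the scatter) shows that the group on that nitrogen can move the number a great deal, whereas compound 3, with its tert-butyl groups, gives a number within the scatter of compound 2. For compound 4 a step of about a 1.3-fold higher number from compound 2 to compound 4 (0.10 log units; within the scatter) is therefore expected, not beyond the scatter. Compound 4 is estimated at 80 nM, with a range from 25 nM to 250 nM.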

Compound 4, half-maximal inhibitory concentration: 530 nM
Beside the measured number, compound 4's estimate is 6.6-fold (0.82 log units) below it, and the stated range ends below it.
By their numbers in this assay, from the lowest: compounds 3 and 2 (each within the scatter of the next); then compounds 4 and 1 (each within the scatter of the next).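

On the aromatic ring carried by the amide-type nitrogen, the substituent itself matters in this assay: phenoxy in place of chloro, on an aromatic carbon ortho to a large group, gives an 8.3-fold higher number from compound 2 to compound 4 (0.92 log units; beyond the scatter). The earlier single-point step exchanged the whole group on that nitrogen, whereas this one keeps the six-membered aromatic ring of carbon only and changes one substituent, so this aromatic carbon is now a place where the number responds on its own. The change brings in seven heavy atoms for one, including a further aromatic ring and an oxygen, and no information bears on why the number moves with this exchange.

One step cannot separate the contribution of the added ring from that of the oxygen linking it, and a methoxy group, which keeps that oxygen without the ring, would bear directly on this point. Going by these compounds, how an amine or a carboxylic acid on the same aromatic carbon would read in this assay also stays open, as does whether any group there can give a lower number than chloro.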